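This account rests on a few compounds, and the source may have more. Where it says the series, first, only, none or still open, it means among the compounds named here.

Three compounds share one core and differ only in the chain attached to the aromatic oxygen. In an assay on isolated protein (Cavia porcellus) with Sigma non-opioid intracellular receptor 1 (Homo sapiens) as the target, read by radioligand binding (a lower number here means a stronger inhibitor, a higher number a weaker inhibitor), compound 1 `CN(C)CCCCCCOc1ccc2oc(-c3ccccc3)cc(=O)c2c1` gives 432 nM, compound 2 `CN(C)CCCCCCCOc1ccc2oc(-c3ccccc3)cc(=O)c2c1` gives 165 nM, and compound 3 `CN(C)CCCCCCCCCCOc1ccc2oc(-c3ccccc3)cc(=O)c2c1` gives 297 nM. Compound 3 stands second highest of the three, within the scatter of both others. Lengthening the chain gave a 2.6-fold lower number from compound 1 to compound 2 (0.42 log units; beyond the scatter), then a 1.5-fold lower number from compound 1 to compound 3 (0.16 log units; within the scatter) and a 1.8-fold higher number from compound 2 to compound 3 (0.26 log units; within the scatter), so chain length alone moved the numbers little. Compound 4 `O=c1cc(-c2ccccc2)oc2ccc(OCCCN3CCC(O)CC3)cc12` differs from compound 3 by 4-hydroxypiperidin-1-yl in place of 7-(dimethylamino)heptyl on a saturated chain carbon, three bonds along the chain from an oxygen on an aromatic ring. Among the measured compounds shown here, no measured step exchanges an open chain end for a ring, so only the weak chain-length trend guides the expectation. In this assay compound 4 is therefore expected to give 500 nM, between 150 nM and 1700 nM, an expected step of a 1.7-fold higher number from compound 3 to compound 4 (0.23 log units; within the scatter).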

Compound 4, half-maximal inhibitory concentration: 130 nM
Estimate against measurement, compound 4: 3.8-fold (0.59 log units) above; measured number outside the range, below it.
By their numbers in this assay, from the lowest: compounds 4, 2, 3 and 1 (each within the scatter of the next, the first and the last beyond it).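

In this assay, a ring at the chain end on a much shorter chain does not cost binding: 4-hydroxypiperidin-1-yl gives a 2.3-fold lower number from compound 3 to compound 4 (0.36 log units; beyond the scatter) and a 3.3-fold lower number from compound 1 to compound 4 (0.52 log units; beyond the scatter). The remaining comparison, a 1.3-fold lower number from compound 2 to compound 4 (0.10 log units; within the scatter), shows no real difference, so among these compounds a long open chain ending in dimethylamino is not needed to reach this level. Nothing available here explains the result. The ring and the chain length change together, so their separate contributions cannot be told apart. A plain piperidine, a morpholine, or 4-hydroxypiperidin-1-yl on a longer chain would help to separate them.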